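This account rests on a few compounds, and the source may have more. Where it says the series, first, only, none or still open, it means among the compounds named here.

Measured compounds:

compound 1 `C=C(C)C(=O)c1ccc(OCc2nc(-c3ccc(C(F)(F)F)cc3)no2)cc1Br` — in an assay on HL-60 cells for inhibition of glutathione S-transferase P (Homo sapiens) (a lower number here means a stronger inhibitor, a higher number a weaker inhibitor), compound 1 gives 1300 nM
compound 2 `C=C(C)C(=O)c1ccc(OCc2nc(-c3ccccc3)no2)cc1C` — in this assay compound 2 gives 1970 nM
compound 3 `C=C(C)C(=O)c1ccc(OCc2nc(C)no2)cc1Br` — in this assay compound 3 gives 3200 nM

Compound 3 stands at the highest of the three numbers. Compound 2 lies within the usual scatter of it, so no order between these two can be read. Compound 1 lies beyond the scatter, with the lower number.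

Compound 4 `C=C(C)C(=O)c1ccc(OCc2nc(-c3ccccc3)no2)cc1Br` is the next member. Relative to compound 3 the change is phenyl in place of methyl on an aromatic carbon; the core and the bromine are kept. Going by the values given here, no pair among the measured compounds differs in one place only, so no measured step can be carried over. What is seen: compound 2 carries the same phenyl with a methyl on the core and gives 1970 nM; compound 1 carries the bromine with a trifluoromethyl-bearing phenyl and gives 1300 nM. Both point toward a number lower than that of compound 3, a step of modest size, likely beyond the scatter but not large.

Compound 4 is expected to give 1500 nM in this assay, within 700 nM to 3500 nM. This estimate means a step of a 2.1-fold lower number from compound 3 to compound 4 (0.33 log units; beyond the scatter), expected because compound 2 shows 1970 nM with the same phenyl in place.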

Compound 4, half-maximal inhibitory concentration: 2000 nM
Estimate against measurement, compound 4: 1.3-fold (0.12 log units) below; low and high end bracket the measured number.
By their numbers in this assay, from the lowest: compounds 1, 2, 4 and 3 (each within the scatter of the next, the first and the last beyond it).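

In this assay, phenyl in place of methyl on an aromatic carbon between two ring nitrogen atoms gives a 1.6-fold lower number from compound 3 to compound 4 (0.20 log units; within the scatter) and so leaves no readable shift at this position, even with a whole aromatic ring entering for a single carbon. On the same compound, bromine taking over from the methyl on the core gives a 1.0-fold higher number from compound 2 to compound 4 (0.01 log units; within the scatter) and thus cannot be told apart from the methyl analogue. Hydrogen in place of trifluoromethyl on an aromatic carbon gives a 1.5-fold higher number from compound 1 to compound 4 (0.19 log units; within the scatter) and likewise stays unresolved, so none of the three single exchanges can be read as a real difference.

No independent measurement bears on these numbers. On these data alone, whether an amine or a carboxylic acid on the phenyl, or a longer chain in place of it, would move the number beyond the scatter remains open.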